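A few compounds are considered here, and "the series" means these few. Any claim that something is new, unique, unknown or untested is made for them only; others in the source may bear on it.

Series values in a functional assay on HCT-116 cells (Homo sapiens) for antiproliferative activity; a higher number here means a weaker inhibitor, a lower number a stronger inhibitor:
- Compound 1 `COc1ccc(-c2snnc2-c2cc(OC)c(OC)c(OC)c2)cc1[N+](=O)[O-]`: 30.2 nM
- Compound 2 `COc1cc(-c2nnsc2-c2ccc([N+](=O)[O-])cc2)cc(OC)c1OC`: > 1000 nM

Compound 2 stands at > 1000 nM, which is a limit of the assay and not a number. The next compound, compound 3 `COc1cc(-c2nnsc2-c2ccc(Cl)cc2)cc(OC)c1OC`, has chloro in place of nitro on an aromatic carbon, para to a large group (chloro in place of nitro on an aromatic carbon). For the measured compounds named here, no measured pair shows this change, so the expectation is loose: no step beyond the scatter is expected in this assay, and the estimated move is a step that the limit leaves unreadable from compound 2 to compound 3. A result at the assay limit is quite likely. For compound 3 the expected value is 1500 nM, with an estimated range of 300 nM to 8000 nM.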

Compound 3, half-maximal inhibitory concentration: 18.5 nM
Beside the measured number, compound 3's estimate is 81-fold (1.91 log units) above it; the measured number lies below the stated range.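

In this assay, chloro in place of nitro on this aromatic carbon, para to a large group, gives an at least 54-fold lower number from compound 2 to compound 3 (1.73 log units; beyond the scatter). For the compounds shown here, this position is therefore sensitive to the group it carries, which the earlier compounds could not show because they formed no single-change pair. Compound 2 stands at a limit, so the full size of the step stays unread because of that limit: the limit of > 1000 nM in this assay, at which 1 of the 3 values shown sits.

From the compounds shown here alone, whether an amine or a carboxylic acid on this carbon would behave like chloro or like nitro stays open. So does whether the step holds with other groups elsewhere on the shared core.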